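Pyrrole for furan on the thiosemicarbazone nitrogen

The source may report more compounds than this note shows. Statements on the series, on what has been measured and on what is new or still open speak of the compounds shown alone.

Compound 1 `CC1=CC[C@H](C(C)(C)NC(=S)NN)CC1`: in a functional assay on U-251 cells (Homo sapiens) for inhibition, read by sulforhodamine B assay, with a stated time of 48 h (on this read-out higher numbers stand for weaker inhibition of growth and lower numbers for stronger inhibition of growth), compound 1 gives 10100 nM.
Compound 2 `CC1=CC[C@H](C(C)(C)NC(=S)N/N=C/c2ccccc2Cl)CC1`: in this assay compound 2 reaches only a limit of the assay, > 100000 nM.
Compound 3 `CC1=CC[C@H](C(C)(C)NC(=S)N/N=C/c2ccco2)CC1`: in this assay compound 3 gives 81500 nM.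

Among the numbers that are numbers, compound 3 holds the highest; compound 1 sits below it by an 8.1-fold higher number from compound 1 to compound 3 (0.91 log units; beyond the scatter), while compound 2 offers a limit only (the limit of > 100000 nM in this assay, at which 1 of the 3 values shown sits). Compound 4 `CC1=CC[C@H](C(C)(C)NC(=S)N/N=C/c2ccc[nH]2)CC1` carries 1H-pyrrol-2-yl in place of furan-2-yl on a carbon with a double bond to nitrogen. Within the data shown here, two measured steps bear on this change. The exchange of one ring for another on the carbon with a double bond to nitrogen, an at least 1.2-fold lower number from compound 2 to compound 3 (0.08 log units; that floor lies within the scatter), stayed within the scatter, whereas an 8.1-fold higher number from compound 1 to compound 3 (0.91 log units; beyond the scatter) concerned the addition of a ring rather than its exchange and is less telling here. Compound 4 is therefore expected to show a step of a 1.2-fold lower number from compound 3 to compound 4 (0.07 log units; within the scatter) in this assay. The estimate for compound 4 is 70000 nM, with a range from 30000 nM to 160000 nM.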

Compound 4, concentration for total growth inhibition: 3900 nM
Estimate against measurement, compound 4: 18-fold (1.25 log units) above, and the stated range ends above it.
By their numbers in this assay, from the lowest: compound 4; then compound 1; then compound 3. At a limit, above all of these: compound 2.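

On a carbon with a double bond to nitrogen, the choice of ring proves decisive in this assay: the exchange of 1H-pyrrol-2-yl for furan-2-yl gives a 21-fold lower number from compound 3 to compound 4 (1.32 log units; beyond the scatter), and the exchange for 2-chlorophenyl gives an at least 25-fold lower number from compound 2 to compound 4 (1.40 log units; beyond the scatter). That second step rests on a limit of the assay for compound 2: the limit of > 100000 nM in this assay, at which 1 of the 4 values shown sits. Adding a ring need not weaken growth inhibition either, as shown by a 2.6-fold lower number from compound 1 to compound 4 (0.41 log units; beyond the scatter). The compounds shown leave open whether a 1-methylpyrrol-2-yl or a thiophen-2-yl group on this carbon would keep the gain.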